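The compounds below may be only part of what the source reports. "The series", "measured", "known", "first", "only" and "open" are said of these compounds alone.

Of the compounds shown here, three sharing one core have been tested in a functional assay on MV4-11 cells (Homo sapiens) for inhibition, read by resazurin assay, with a stated time of 72 h; on this read-out higher numbers stand for weaker inhibition of growth and lower numbers for stronger inhibition of growth. In this assay, compound 1 `Cc1ccc(-c2cncc(Cl)c2N2CCC3(CCNC3=O)CC2)s1` gives 650 nM, compound 2 `O=Cc1ccc(-c2cncc(Cl)c2N2CCC3(CCNC3=O)CC2)s1` gives 750 nM and compound 3 `O=C1NCCC12CCN(c1c(Cl)cncc1-c1ccc(CN3CCCCC3)s1)CC2` gives 4010 nM. Compound 2 has the second highest of the three numbers. Its nearest neighbour shows a 1.2-fold higher number from compound 1 to compound 2 (0.06 log units; within the scatter), and its furthest shows a 5.3-fold higher number from compound 2 to compound 3 (0.73 log units; beyond the scatter).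

The next compound is compound 4 `O=C1NCCC12CCN(c1c(Cl)cncc1-c1cn[nH]c1)CC2`, and the change is 1H-pyrazol-4-yl in place of 5-formylthiophen-2-yl on an aromatic carbon. In words, 1H-pyrazol-4-yl stands in place of 5-formylthiophen-2-yl on an aromatic carbon. Among the measured compounds shown here, no measured step replaces the whole 5-formylthiophen-2-yl group, so the evidence is only indirect. It comes from changes to what that group carries. Beyond the step already given for formyl in place of methyl, the other measured change gave a 6.2-fold higher number from compound 1 to compound 3 (0.79 log units; beyond the scatter). Both steps beyond the scatter lead to compound 3, which carries a piperidin-1-yl group that compound 4 lacks, so they are a weak guide here. In this assay, therefore, only a small upward step, within the scatter, is expected, with wide uncertainty. The expected step is a 1.3-fold higher number from compound 2 to compound 4 (0.12 log units; within the scatter). For compound 4 the estimated value is 1000 nM, with an expected range from 300 nM to 3500 nM.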

Compound 4, concentration for 50% growth inhibition: 8520 nM
Compound 4: the middle estimate sits 8.5-fold (0.93 log units) below what was measured; the whole stated range lies below it.
By their numbers in this assay, from the lowest: compounds 1 and 2 (each within the scatter of the next); then compound 3; then compound 4.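

In this assay, this place on the six-membered aromatic ring, ortho to a large group, responds far more strongly to an exchange of the whole five-membered ring than the earlier changes to what the thiophene carries had suggested. 1H-pyrazol-4-yl in place of 5-formylthiophen-2-yl gives an 11-fold higher number from compound 2 to compound 4 (1.06 log units; beyond the scatter), and in place of 5-methylthiophen-2-yl it gives a 13-fold higher number from compound 1 to compound 4 (1.12 log units; beyond the scatter), both larger than the step seen when the thiophene's substituent was changed, a 5.3-fold higher number from compound 2 to compound 3 (0.73 log units; beyond the scatter). The exchange alters several things at once, removing the substituent, replacing the ring sulfur with two ring nitrogens and bringing in a hydrogen-bond donor, and no measurement at hand explains the loss or assigns it to any one of these features.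

The compounds shown leave open whether the thiophene itself or its substituent matters more, since an unsubstituted thiophen-2-yl group does not appear among them. They also leave open whether a pyrazole carrying a methyl group, or one with its ring nitrogen capped by a methyl group, would recover the growth inhibition seen with compound 1 at 650 nM.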